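The source may hold more compounds than are shown below. What is called first, only, known or untested is meant among the compounds shown, and "the series" means these compounds.

Working notes on the series in an ADME assay on MDCK cells (Canis lupus familiaris) for cytotoxicity, read by microscopy, with a stated time of 48 h; a lower number here means that less compound is tolerated, a higher number that more compound is tolerated.

Compound 1 `C[C@H]1[C@H](NCc2sccc2Br)C[C@H]2C[C@@H]1C2(C)C` gives 50000 nM in this assay, the highest of the two plain numbers in the set; the nearest is compound 2 `C[C@H]1[C@H](NCc2ccc(Br)s2)C[C@H]2C[C@@H]1C2(C)C` at 43000 nM, and the step of a 1.2-fold lower number from compound 1 to compound 2 (0.07 log units; within the scatter) sits within the scatter. Compound 3 `Cc1csc(CN[C@@H]2C[C@H]3C[C@@H]([C@H]2C)C3(C)C)n1` returns only a limit of the assay, > 100000 nM. That limit appears as the limit of > 100000 nM in this assay, at which 1 of the 3 values shown sits. The steps of an at least 2.0-fold higher number from compound 1 to compound 3 (0.30 log units; that floor lies within the scatter) and an at least 2.3-fold higher number from compound 2 to compound 3 (0.36 log units; beyond the scatter) are therefore floors rather than fixed sizes.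

Compound 4 `CCc1ccsc1CN[C@@H]1C[C@H]2C[C@@H]([C@H]1C)C2(C)C` differs from compound 1 by ethyl in place of bromo on an aromatic carbon, on an aromatic carbon of a five-membered aromatic ring with 1 sulfur. Within the data shown here, no measured step exchanges bromo for ethyl; the step of a 1.2-fold lower number from compound 1 to compound 2 (0.07 log units; within the scatter) moves the bromo within the same ring without a change beyond the scatter, and the only steps beyond it involve a different ring altogether. The step of no change at the digits printed from compound 1 to compound 4 (within the scatter) is thus expected to stay within the scatter. Compound 4 is estimated at 50000 nM in this assay, with a range from 25000 nM to 100000 nM.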

Compound 4, minimum cytotoxic concentration: 25000 nM
Compound 4: middle estimate off by 2.0-fold (0.30 log units), on the high side; measured number inside the range.
By their numbers in this assay, from the lowest: compounds 4, 2 and 1 (each within the scatter of the next). At a limit, above all of these: compound 3.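

Among these compounds, this is the first change of the group itself on this ring carbon, rather than a move of the bromo or a switch to another ring. In this assay, ethyl in place of bromo, next to the ring atom that bears a large group and two ring bonds from the ring sulfur, gives a 2.0-fold lower number from compound 1 to compound 4 (0.30 log units; within the scatter) and so adds one heavy atom without a change beyond the scatter. Nothing at hand gives a cause for this step.

From the compounds shown here alone, whether an amine, a carboxylic acid or a longer chain on this same carbon would also stay within the scatter of compound 1 remains open. Also open, going by these compounds, is whether the exchange of bromo for ethyl on compound 2 would give a step of similar size.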